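From 4-ethylphenyl to phenethyl on a sulfur

This account rests on a few compounds, and the source may have more. Where it says the series, first, only, none or still open, it means among the compounds named here.

For the measured compounds named here, in a functional assay on SMMC-7721 cells (Homo sapiens) for inhibition, read by CCK-8 assay, with a stated time of 72 h, tested at 8 uM (on this read-out lower numbers stand for less inhibition of growth and higher numbers for more inhibition of growth at the one concentration tested), compound 1 (`CCc1ccc(SCc2ccc(C(=O)Nc3ccccc3N)cc2)cc1`) gives 82.9%, the highest of the three numbers measured so far. Compound 2 (`CC(C)(C)c1ccc(SCc2ccc(C(=O)Nc3ccccc3N)cc2)cc1`) gives 46.1% and compound 3 (`Nc1ccccc1NC(=O)/C=C/c1ccc(CSCCc2ccccc2)cc1`) gives 15.8%, and both numbers lie lower than that of compound 1 by more than the scatter.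

Compound 4 (`Nc1ccccc1NC(=O)c1ccc(CSCCc2ccccc2)cc1`) has not yet been measured. It has the same atoms as compound 1, joined differently: phenethyl in place of 4-ethylphenyl on a sulfur. In words, phenethyl stands in place of 4-ethylphenyl on a sulfur.

Going by the values given here, only one measured step touches this group: a number 36.8 percentage points lower from compound 1 to compound 2 (beyond the scatter). Among the compounds with values here, this large step, with tert-butyl in place of ethyl on an aromatic carbon, shows that the number can move far with a change there, but no measured step replaces the whole group. Compound 3 also carries phenethyl on the sulfur and stands at 15.8%, although its core differs from that of compound 4. Both observations point downward, so a large fall is expected, with much uncertainty about its size. The expected change is a number 40.9 percentage points lower from compound 1 to compound 4 (beyond the scatter). For compound 4 the estimated value is 42%, with an expected range from 15% to 70%.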

Compound 4, percent growth inhibition at one concentration: 77.9%
Estimate against measurement, compound 4: 35.9 percentage points below; measured number above the stated range.
By their numbers in this assay, from the lowest: compound 3; then compound 2; then compounds 4 and 1 (each within the scatter of the next).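

In this assay, the step to phenethyl on the sulfur gives a number 5 percentage points lower from compound 1 to compound 4 (within the scatter), so this position tolerates a rearrangement of the same eight carbons, and the group need not be 4-ethylphenyl for the number to stay in this range. The sensitivity seen in a number 36.8 percentage points lower from compound 1 to compound 2 (beyond the scatter) therefore does not extend to every change at this group: tert-butyl in place of ethyl on an aromatic carbon moves the number far, whereas this exchange of the whole group does not. Phenethyl on the sulfur also does not go with a low number by itself, since compound 3 gives 15.8% and compound 4 gives 77.9% with that same group, and no measurement given here explains the result of this exchange.

The compounds shown leave open whether a longer chain or an amine in place of phenethyl on a sulfur would keep the number in this range. They also leave open whether compound 1 and compound 4 would stay within the scatter of each other at other concentrations or in other cells.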